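Vinylsulfonyl in Place of Propynyl Amide on the Warhead

This account rests on a few compounds, and the source may have more. Where it says the series, first, only, none or still open, it means among the compounds named here.

Measured compounds:
compound 1, `C=CC(=O)Nc1ccccc1Nc1ncc2c(-c3cc(OC)cc(OC)c3)n[nH]c2n1`, 4090 nM
compound 2, `C=CC(=O)Nc1ccccc1Nc1ccc2c(C(=O)c3cc(OC)cc(OC)c3)c[nH]c2n1`, 140 nM
compound 3, `CC#CC(=O)Nc1ccccc1Nc1ccc2c(C(=O)c3cc(OC)cc(OC)c3)c[nH]c2n1`, 602 nM

In a functional assay on Hep 3B2 cells (Homo sapiens) for antiproliferative activity, with a stated time of 72 h (on this read-out lower numbers stand for stronger inhibition and higher numbers for weaker inhibition), compound 3 gives 602 nM, the second highest of the three numbers; compound 2 gives 140 nM and compound 1 gives 4090 nM. Compound 4, `C=CS(=O)(=O)Nc1ccccc1Nc1ccc2c(C(=O)c3cc(OC)cc(OC)c3)c[nH]c2n1`, has not yet been measured. It differs from compound 3 by vinylsulfonyl in place of (prop-1-yn-1-yl)carbonyl on a nitrogen on an aromatic ring. Within the data shown here, the only measured step that bears on this change is a 4.3-fold higher number from compound 2 to compound 3 (0.63 log units; beyond the scatter), which shows that the vinyl group on the carbonyl carbon gives the lower number. Among the measured compounds shown here, compound 4 brings a vinyl group back, but there is no measured step for carbonyl against sulfonyl on this nitrogen. The step of a 1.5-fold lower number from compound 3 to compound 4 (0.18 log units; within the scatter) is therefore expected to move back toward the number of compound 2, with wide uncertainty. Compound 4 is estimated at 400 nM, with a range from 100 nM to 1600 nM.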

Compound 4, half-maximal inhibitory concentration: 1030 nM
Compound 4: middle estimate off by 2.6-fold (0.41 log units), on the low side; measured number inside the range.
By their numbers in this assay, from the lowest: compound 2; then compounds 3 and 4 (each within the scatter of the next); then compound 1.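

In this assay, the change from carbonyl to sulfonyl with the vinyl group held in place on this nitrogen gives a step beyond the scatter (a 7.4-fold higher number from compound 2 to compound 4 (0.87 log units; beyond the scatter)), so the lower number seen with vinylcarbonyl in compound 2 does not carry over to vinylsulfonyl. Vinylsulfonyl and (prop-1-yn-1-yl)carbonyl cannot be told apart at this position (a 1.7-fold higher number from compound 3 to compound 4 (0.23 log units; within the scatter)), which shows that a vinyl group alone does not bring the number back toward that of compound 2. Nothing measured here accounts for the gap between the carbonyl and the sulfonyl.

The compounds shown leave open whether a methylsulfonyl group or a chloroacetyl group on this nitrogen would stand nearer compound 2 or compound 4. They also leave open whether vinylsulfonyl would behave the same way on the core of compound 1.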